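The source may hold more compounds than are shown below. What is called first, only, known or untested is meant among the compounds shown, and "the series" means these compounds.

Measured so far:
- compound 1 `Cc1cc(Cl)ccc1OC(C)C(=O)N/N=C/c1ccccc1OC(F)(F)F`: "not active" (no number reported)
- compound 2 `Cc1cc(Cl)ccc1OCC(=O)N/N=C/c1ccccc1F`: "not active" (no number reported)
- compound 3 `Cc1cc(Cl)ccc1OCc1nnc(-c2ccccc2F)o1`: > 100000 nM

All three compounds share the same left-hand core. In an ADME assay on cells for inhibition of anoctamin-2 (Homo sapiens), read by fluorescence, with a stated time of 20 min (on this read-out higher numbers stand for weaker inhibition and lower numbers for stronger inhibition), compound 1 is recorded as "not active" (no number reported). In this assay compound 2 is likewise recorded as "not active" (no number reported). For compound 3 the entry is a limit of the assay rather than a number, > 100000 nM. One of the three entries therefore sits at the limit of > 100000 nM in this assay, at which 1 of the 3 values shown sits. Compound 2 thus stands without a number of its own, alongside one further limit and one further entry with no number, so no ordering among the three can be drawn.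

Compound 4 `Cc1cc(Cl)ccc1OCC(=O)N/N=C/c1ccccc1OC(F)(F)F` is the next compound to be tested. It differs from compound 2 by trifluoromethoxy in place of fluoro on an aromatic carbon. Among the measured compounds shown here, no step between measured compounds has been recorded, so in this assay no shift beyond the usual scatter is expected in either direction, and compound 4 is expected to stay without measurable inhibition. Compound 4 is estimated at 150000 nM, with a range from 30000 nM to 1000000 nM.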

Compound 4, half-maximal inhibitory concentration: "not active" (no number reported)
The entry for compound 4 holds no number; no gap can be computed for the estimate.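

Compound 2 and compound 4 both stand without a number in this assay, so no step can be read between them. The compounds shown leave open whether any change to the shared core gives measurable inhibition, as the only other entry is a limit: the limit of > 100000 nM in this assay, at which 1 of the 4 values shown sits.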